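Methoxy for methylamino on a nucleoside core in fibroblast cells

The source may report more compounds than this note shows. Statements on the series, on what has been measured and on what is new or still open speak of the compounds shown alone.

Measured compounds:
compound 1, `COc1ncnc2c1c(-c1ccsc1)cn2[C@@H]1O[C@H](CO)[C@@H](O)[C@H]1O`, 75300 nM
compound 2, `CNc1ncnc2c1c(-c1ccco1)cn2[C@@H]1O[C@H](CO)[C@@H](O)[C@H]1O`, 90800 nM

The two compounds were tested in an ADME assay on MRC5 cells (Homo sapiens), read by MTT assay, with a stated time of 72 h; a lower number here means a stronger inhibitor, a higher number a weaker inhibitor. Compound 1 gives 75300 nM, and compound 2 gives 90800 nM. The numbers of compound 2 and compound 1 lie close together, within the usual scatter of repeated measurements, so neither can be set apart from the other.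

Compound 3, `COc1ncnc2c1c(-c1ccco1)cn2[C@@H]1O[C@H](CO)[C@@H](O)[C@H]1O`, has not yet been measured. It differs from compound 2 in one place: methoxy in place of methylamino on an aromatic carbon. Compound 1 already carries a methoxy on the shared core and sits within the scatter of compound 2, so for this change no step beyond the scatter is expected in either direction. Compound 3 is therefore expected to give about 78000 nM, with a range from 35000 nM to 170000 nM, which amounts to an expected step of a 1.2-fold lower number from compound 2 to compound 3 (0.07 log units; within the scatter).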

Compound 3, half-maximal inhibitory concentration: 1700 nM
The estimate for compound 3 lay 46-fold (1.66 log units) above the measured number; measured number outside the range, below it.
By their numbers in this assay, from the lowest: compound 3; then compounds 1 and 2 (each within the scatter of the next).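

In this assay, methoxy in place of methylamino on the aromatic carbon next to the ring nitrogen brings a 53-fold lower number from compound 2 to compound 3 (1.73 log units; beyond the scatter) with furan-2-yl held constant, so this position is far from indifferent to the change. With methoxy held constant, furan-2-yl in place of thiophen-3-yl brings a 44-fold lower number from compound 1 to compound 3 (1.65 log units; beyond the scatter) on the same core, so methoxy does not give the low number with every neighbouring group. Among these compounds only compound 3 carries methoxy and furan-2-yl together, and it alone stands apart, which compound 1 and compound 2 could not show on their own.

On these data alone, whether an unsubstituted amine, ethoxy or chlorine at this carbon would keep the low number remains open, as does how other rings in place of furan-2-yl would behave beside methoxy. No measurement shown here accounts for the size of these steps.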